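The source may hold more compounds than are shown below. What is called first, only, known or untested is meant among the compounds shown, and "the series" means these compounds.

Measured compounds:
Compound 1, `COc1cc(-c2cc(/C=C/C(=O)c3ccc(N)cc3)[nH]n2)cc(OC)c1OC`: 8510 nM
Compound 2, `COc1ccc(-c2cc(/C=C/C(=O)c3ccc(N)cc3)[nH]n2)cc1OC`: 16500 nM
Compound 3, `COc1cc(C(=O)/C=C/c2cc(-c3cc(OC)c(OC)c(OC)c3)n[nH]2)cc(OC)c1OC`: 8950 nM

In a functional assay on MOLT-4 cells (Homo sapiens) for inhibition, read by sulforhodamine B assay, with a stated time of 48 h (on this read-out lower numbers stand for stronger inhibition of growth and higher numbers for weaker inhibition of growth), compound 1 gives 8510 nM. The change from compound 1 to compound 2 is hydrogen in place of methoxy on an aromatic carbon; in this assay compound 2 gives 16500 nM, and the step is a 1.9-fold higher number from compound 1 to compound 2 (0.29 log units; within the scatter). Compound 3 gives 8950 nM in this assay; the difference between the core of compound 3 and that of compound 1 is not broken down here, and their two values lie within the scatter of each other.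

Compound 4, `COc1ccc(-c2cc(/C=C/C(=O)c3cc(OC)c(OC)c(OC)c3)[nH]n2)cc1OC`, has not yet been measured. It differs from compound 3 by hydrogen in place of methoxy on an aromatic carbon, the same change as that from compound 1 to compound 2, at a place described in the same words. For compound 4 a step of a 1.8-fold higher number from compound 3 to compound 4 (0.25 log units; within the scatter) is therefore expected in this assay, because the earlier instance gave a 1.9-fold higher number from compound 1 to compound 2 (0.29 log units; within the scatter). Compound 4 is estimated at 16000 nM, within 7000 nM to 40000 nM.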

Compound 4, concentration for total growth inhibition: 8860 nM
The estimate for compound 4 lay 1.8-fold (0.26 log units) above the measured number; the range from low to high includes it.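

In this assay, putting hydrogen in place of methoxy on an aromatic carbon gives a 1.0-fold lower number from compound 3 to compound 4 (0.00 log units; within the scatter). Set beside the earlier instance of the same change, this step cannot be told apart from it: the same change on two cores in this assay, a 1.9-fold higher number (0.29 log units; within the scatter) from compound 1 to compound 2 and a 1.0-fold lower number (0.00 log units; within the scatter) from compound 3 to compound 4, 2.0-fold (0.29 log units) apart, within the scatter of two such steps The two cores are therefore compatible with the change carrying over, but both steps are small enough to be scatter, so the data show neither a real effect of this methoxy group on either core nor a difference between the cores.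

On these data alone, how a hydroxy group, a fluorine atom or a longer alkoxy chain at that place would read in this assay stays open. So does the outcome of exchanging the amine of compound 1 for a carboxylic acid.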